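Notes on the aryl substituent of the biaryl amide series

The source may report more compounds than this note shows. Statements on the series, on what has been measured and on what is new or still open speak of the compounds shown alone.

Compound 1 `Cc1cc(-c2nc(C(F)(F)F)ccc2CNC(=O)C(C)c2ccc(NS(C)(=O)=O)c(F)c2)ccc1F` gives 0.4 nM in an assay on CHO cells for antagonist activity at transient receptor potential cation channel subfamily V member 1 (Homo sapiens), read by FLIPR; on this read-out higher numbers stand for weaker inhibition and lower numbers for stronger inhibition. For the measured compounds named here, compound 2 `COc1ccc(-c2nc(C(F)(F)F)ccc2CNC(=O)C(C)c2ccc(NS(C)(=O)=O)c(F)c2)cc1F` gives 4.2 nM in this assay, the highest of the two numbers so far; the only measured step is an 11-fold higher number from compound 1 to compound 2 (1.02 log units; beyond the scatter). Compound 3 `COc1ccc(-c2nc(C(F)(F)F)ccc2CNC(=O)C(C)c2ccc(NS(C)(=O)=O)c(F)c2)cc1OC` has not been measured. Compound 3 differs from compound 2 by methoxy in place of fluoro on an aromatic carbon, so that 3-fluoro-4-methoxyphenyl becomes 3,4-dimethoxyphenyl. Going by the values given here, no measured pair changes exactly this position; the single step of an 11-fold higher number from compound 1 to compound 2 (1.02 log units; beyond the scatter) concerns the same aryl ring and shows that its substitution pattern can move the number strongly, so a change here may again be felt, though its direction is not settled by the data. Compound 3 is expected to give a somewhat higher number than compound 2, a step of a 1.9-fold higher number from compound 2 to compound 3 (0.28 log units; within the scatter) in this assay. The estimate for compound 3 in this assay is 8 nM, within 2.5 nM to 30 nM.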

Compound 3, inhibition constant: 25.6 nM
Compound 3: middle estimate off by 3.2-fold (0.51 log units), on the low side; the range from low to high includes it.
By their numbers in this assay, from the lowest: compound 1; then compound 2; then compound 3.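

In this assay, the place that carries fluoro in compound 2 proves sensitive on its own: methoxy there gives a 6.1-fold higher number from compound 2 to compound 3 (0.78 log units; beyond the scatter). The earlier step changed two places on the aryl ring together, so it could not show this. Across the three aryl patterns, 3,4-dimethoxyphenyl now gives the highest number and 4-fluoro-3-methylphenyl the lowest, with a 64-fold higher number from compound 1 to compound 3 (1.81 log units; beyond the scatter); nothing available explains the rise seen with methoxy in place of fluoro.

The compounds shown leave open how the number responds at this place to groups other than fluoro and methoxy, such as a hydroxy group, an ethoxy group or an amine. Also open, from the compounds shown here alone, is whether the step from fluoro to methoxy keeps its size when the neighbouring methoxy group is replaced by another group.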